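Triazine Aryl Ethers: Estimating a Chloro-Methyl Analogue

This account rests on a few compounds, and the source may have more. Where it says the series, first, only, none or still open, it means among the compounds named here.

Compound 1, `CN1CCN(c2nc(N)nc(COc3cccc(Cl)c3)n2)CC1`: 148 nM
Compound 2, `Cc1ccccc1OCc1nc(N)nc(N2CCN(C)CC2)n1`: 87 nM
Compound 3, `Cc1ccc(OCc2nc(N)nc(N3CCN(C)CC3)n2)cc1`: 235 nM

All three compounds were tested in an assay on HEK293 cells for displacement of a labelled ligand from 5-hydroxytryptamine receptor 6 (Homo sapiens), read by radioligand binding, with a stated time of 1 h; a lower number here means a stronger inhibitor, a higher number a weaker inhibitor. Compound 3 gives the highest number of the three; its gap to compound 1 is within the scatter, whereas the step of a 2.7-fold higher number from compound 2 to compound 3 (0.43 log units; beyond the scatter) lies beyond it. Compound 4, `Cc1cc(Cl)ccc1OCc1nc(N)nc(N2CCN(C)CC2)n1`, has not yet been measured; the change is 4-chloro-2-methylphenyl in place of 4-methylphenyl on an oxygen on a saturated carbon. For the measured compounds named here, two measured steps bear on this. The step of a 2.7-fold higher number from compound 2 to compound 3 (0.43 log units; beyond the scatter) shows that 2-methylphenyl gives a lower number than 4-methylphenyl, and the step of a 1.6-fold higher number from compound 1 to compound 3 (0.20 log units; within the scatter) shows that 3-chlorophenyl and 4-methylphenyl differ only within the scatter. Since compound 4 carries the 2-methyl group and adds a chlorine, a modest step downward is expected: a 2.9-fold lower number from compound 3 to compound 4 (0.47 log units; beyond the scatter). Compound 4 is therefore estimated at 80 nM, with a range from 30 nM to 200 nM.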

Compound 4, inhibition constant: 911 nM
The estimate for compound 4 lay 11-fold (1.06 log units) below the measured number; the whole stated range lies below it.
By their numbers in this assay, from the lowest: compounds 2, 1 and 3 (each within the scatter of the next, the first and the last beyond it); then compound 4.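

Chloro in place of hydrogen on the 2-methylphenyl group gives a 10-fold higher number from compound 2 to compound 4 (1.02 log units; beyond the scatter) and removes the advantage that 2-methylphenyl showed over 4-methylphenyl. The other two comparisons point the same way, with a 3.9-fold higher number from compound 3 to compound 4 (0.59 log units; beyond the scatter) and a 6.2-fold higher number from compound 1 to compound 4 (0.79 log units; beyond the scatter), so the lower number seen with 2-methylphenyl does not survive the added chloro. Nothing measured here explains this rise. On these data alone, what stays open is whether the rise is particular to chloro, since a fluoro, methoxy or amine group in its place on the same ring could behave differently.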